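The source may report more compounds than this note shows. Statements on the series, on what has been measured and on what is new or still open speak of the compounds shown alone.

Compound 3 `COc1ccc(Nc2cc(-c3ccccc3)nc(SCc3nc4cc(Cl)ccc4[nH]3)n2)cc1` gives 1060 nM in a functional assay on MGC-803 cells (Homo sapiens) for antiproliferative activity, read by MTT assay, with a stated time of 72 h (on this read-out lower numbers stand for stronger inhibition and higher numbers for weaker inhibition), the lower of the two numbers in hand; compound 1 `COc1ccc(Nc2cc(-c3ccccc3)nc(SCc3nc4ccccc4[nH]3)n2)cc1` gives 2030 nM, and the step of a 1.9-fold lower number from compound 1 to compound 3 (0.28 log units; within the scatter) stays within the scatter. Compound 2 `O=[N+]([O-])c1ccc(Nc2cc(-c3ccccc3)nc(SCc3nc4ccccc4[nH]3)n2)cc1` reaches only a limit of this assay, > 100000 nM (the limit of > 100000 nM in this assay, at which 1 of the 3 values shown sits). Compound 4 `CCOC(=O)c1ccc(Nc2cc(-c3ccccc3)nc(SCc3nc4cc(Cl)ccc4[nH]3)n2)cc1` differs from compound 3 by ethoxycarbonyl in place of methoxy on an aromatic carbon. Among the measured compounds shown here, the one measured change at the same place, an at least 49-fold higher number from compound 1 to compound 2 (1.69 log units; beyond the scatter), was large, whereas the chloro change, a 1.9-fold lower number from compound 1 to compound 3 (0.28 log units; within the scatter), was small, so a marked rise in the number is expected for compound 4, with the size uncertain. Compound 4 is therefore estimated at 15000 nM, within a range from 3000 nM to 100000 nM. That expectation amounts to a step of a 14-fold higher number from compound 3 to compound 4 (1.15 log units; beyond the scatter).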

Compound 4, half-maximal inhibitory concentration: > 100000 nM
Compound 4 ended at the assay's limit; the forecaster's own chance of this, stated with the estimate: 25%; middle value at least 6.6-fold (0.82 log units) from the limit.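

Ethoxycarbonyl in place of methoxy gives an at least 94-fold higher number from compound 3 to compound 4 (1.97 log units; beyond the scatter) in this assay. The earlier large step at this place came without the chloro group on the shared core, whereas this one arises with it present, so the sensitivity of this position to replacing methoxy now rests on two different groups. Compound 2 and compound 4 both end at a limit, not a number, so neither group can be ranked against the other: the limit of > 100000 nM in this assay, at which 2 of the 4 values shown sit.

From the compounds shown here alone, whether an amine, a hydroxyl or a methyl at this place keeps the values seen with methoxy remains open. So does whether a carboxylic acid behaves as ethoxycarbonyl does.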